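Swapping 2,3-dimethoxyphenyl for 4-chlorophenyl: compound 1 to compound 4

A few compounds are considered here, and "the series" means these few. Any claim that something is new, unique, unknown or untested is made for them only; others in the source may bear on it.

Measured so far in a functional assay on microsomes for inhibition, with a stated time of 1 h; a higher number here means a weaker inhibitor, a lower number a stronger inhibitor
Compound 1 `CCOC(=O)c1cnn(-c2nc(-c3cccc(OC)c3OC)c(C#N)c(=O)n2C)c1N` gives 57 ug/mL
Compound 2 `CSc1nc(-c2cccs2)c(C#N)c(=O)n1C` gives 83 ug/mL
Compound 3 `COc1cccc(-c2nc(NN)n(C)c(=O)c2C#N)c1OC` gives 37 ug/mL

Compound 1 (57 ug/mL) stands in the middle of the three numbers, and its gaps to compound 2 and to compound 3 both lie within the usual scatter of repeated measurements. The next compound to be tested is compound 4 `CCOC(=O)c1cnn(-c2nc(-c3ccc(Cl)cc3)c(C#N)c(=O)n2C)c1N`, which keeps the rest of compound 1 and changes one group. 4-chlorophenyl in place of 2,3-dimethoxyphenyl on an aromatic carbon In words, 4-chlorophenyl takes the place of 2,3-dimethoxyphenyl on an aromatic carbon, ortho to a cyano group and next to the ring nitrogen.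

Among the compounds with values here, no pair of measured compounds differs in only one place, so the data give no direct measure of this change. Within the data shown here, the only guide is the narrow spread of the numbers, since compound 2 (83 ug/mL) and compound 3 (37 ug/mL) both remain within the scatter of compound 1 despite carrying different groups. The estimated step of a 1.1-fold lower number from compound 1 to compound 4 (0.06 log units; within the scatter) is therefore expected to stay within the scatter, with no clear direction. The expected value for compound 4 is 50 ug/mL (estimated range 22 ug/mL to 115 ug/mL).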

Compound 4, half-maximal inhibitory concentration: 88 ug/mL
Compound 4: middle estimate off by 1.8-fold (0.25 log units), on the low side, within the range that was stated.
By their numbers in this assay, from the lowest: compounds 3, 1, 2 and 4 (each within the scatter of the next, the first and the last beyond it).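

In this assay, the exchange at this position now has a direct measure: 4-chlorophenyl in place of 2,3-dimethoxyphenyl gives a 1.5-fold higher number from compound 1 to compound 4 (0.19 log units; within the scatter) with the rest of the molecule unchanged. On this aromatic carbon, ortho to a cyano group and next to the ring nitrogen, one six-membered aromatic ring of carbon only can therefore replace another without a step beyond the scatter, although the entering group has fewer heavy atoms and no hydrogen-bond acceptors, while the leaving group has two. No measurement is available that bears on why the two groups give numbers within the scatter of each other.

The compounds shown leave open whether an amine, a carboxylic acid or a longer alkyl chain on this same aromatic carbon, in place of the substituted phenyl ring, would give a step beyond the scatter. They also leave open whether a hydroxyl group or a bromine atom in place of the chlorine of 4-chlorophenyl would keep the number within the scatter of compound 4 at 88 ug/mL in this assay.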